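The compounds below may be only part of what the source reports. "The series", "measured", "known", "first", "only" and "open" are said of these compounds alone.

In a functional assay on Molt4/C8 cells (Homo sapiens) for inhibition (on this read-out higher numbers stand for weaker inhibition and lower numbers for stronger inhibition), compound 1 `O=C1/C(=C/c2ccccc2F)CCc2ccccc21` gives 36000 nM. Compound 3 `O=C1/C(=C/c2ccccc2[N+](=O)[O-])CCc2ccccc21` differs from it by nitro in place of fluoro on an aromatic carbon and in this assay compound 3 gives 8120 nM, a step of a 4.4-fold lower number from compound 1 to compound 3 (0.65 log units; beyond the scatter). Compound 2 `O=C1/C(=C/c2ccccc2F)Cc2ccccc21` has a different core; how the two cores differ is not broken down here. In this assay compound 2 gives 54200 nM, which lies within the usual scatter of the number for compound 1. Compound 4 `O=C1/C(=C/c2ccccc2[N+](=O)[O-])Cc2ccccc21` is related to compound 2 by nitro in place of fluoro on an aromatic carbon, the same change that was made from compound 1 to compound 3. Because the step of a 4.4-fold lower number from compound 1 to compound 3 (0.65 log units; beyond the scatter) was modest but beyond the scatter, a step of the same kind is expected from compound 2 to compound 4, namely a 4.2-fold lower number from compound 2 to compound 4 (0.62 log units; beyond the scatter). Compound 4 is therefore estimated to give 13000 nM, somewhere between 5000 nM and 35000 nM.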

Compound 4, half-maximal inhibitory concentration: 2540 nM
For compound 4 the middle estimate is 5.1-fold (0.71 log units) above the measured one, outside the stated range (below it).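

Nitro in place of fluoro on an aromatic carbon brings a 21-fold lower number from compound 2 to compound 4 (1.33 log units; beyond the scatter) in this assay, a large step. The change lowers the number on both cores, but the size of the step does not carry over from one core to the other: the same change on two cores in this assay, a 4.4-fold lower number (0.65 log units; beyond the scatter) from compound 1 to compound 3 and a 21-fold lower number (1.33 log units; beyond the scatter) from compound 2 to compound 4, 4.8-fold (0.68 log units) apart, beyond the scatter of two such steps. This shows that the direction held across these two cores while the size did not, but a single pair of steps does not show why they differ or how the change would behave on any further core.

The compounds shown leave open whether another group on that aromatic carbon, such as an amine, a nitrile or a carboxylic acid, would give a similar difference between the cores. They also leave open whether the same difference would appear with a methoxy group in place of fluoro.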